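Coumarin series: ester replaces hydroxymethyl at the ring position

The source may hold more compounds than are shown below. What is called first, only, known or untested is meant among the compounds shown, and "the series" means these compounds.

Of the compounds shown here, two of the shared core have numbers so far. In an assay on isolated protein (strain Sprague-Dawley) for inhibition of Amine oxidase [flavin-containing] B (Rattus norvegicus), read by spectrophotometry, with a stated time of 5 min (a lower number here means a stronger inhibitor, a higher number a weaker inhibitor), compound 1 `CC(=O)COc1cc(=O)oc2cc(OCc3cccc(Cl)c3)ccc12` gives 26.9 nM and compound 2 `O=c1cc(CO)c2ccc(OCc3cccc(Cl)c3)cc2o1` gives 5.25 nM. Going by the values given here, compound 2 therefore stands lowest of the two, with compound 1 as its only neighbour; the one step in the set, a 5.1-fold lower number from compound 1 to compound 2 (0.71 log units; beyond the scatter), is the only measured change at this ring position.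

Compound 3 `CCOC(=O)c1cc(=O)oc2cc(OCc3cccc(Cl)c3)ccc12` is next for this assay . The change from compound 2 is ethoxycarbonyl in place of hydroxymethyl on an aromatic carbon. Among the compounds with values here, the only step that bears on it, a 5.1-fold lower number from compound 1 to compound 2 (0.71 log units; beyond the scatter), shows that a small hydroxymethyl at this carbon gave a lower number than a larger 2-oxopropoxy group. Ethoxycarbonyl is again a larger group with no hydrogen-bond donor, so a move back toward a higher number is expected, of about a 3.8-fold higher number from compound 2 to compound 3 (0.58 log units; beyond the scatter). Compound 3 is thus estimated at 20 nM in this assay , with a range from 5 nM to 80 nM.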

Compound 3, half-maximal inhibitory concentration: 417 nM
Compound 3: middle estimate off by 21-fold (1.32 log units), on the low side; measured number outside the range, above it.
By their numbers in this assay, from the lowest: compound 2; then compound 1; then compound 3.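

In this assay, the ring carbon opposite the ring oxygen proves far more sensitive to the choice of group than the earlier step indicated: the change to ethoxycarbonyl gives a 79-fold higher number from compound 2 to compound 3 (1.90 log units; beyond the scatter). The two groups larger than hydroxymethyl also do not read alike, since the step from the 2-oxopropoxy compound gives a 16-fold higher number from compound 1 to compound 3 (1.19 log units; beyond the scatter), so ethoxycarbonyl is the poorest of the three groups at this carbon. No measurement on hand accounts for this gap.

As far as these compounds go, it remains open whether the high number follows the ester carbonyl or the ethyl part of the group. A methyl ester, a carboxylic acid or a primary amide at this carbon would help separate those two readings.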